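Swapping fluoro for 4-fluorophenoxy in compound 2

This account rests on a few compounds, and the source may have more. Where it says the series, first, only, none or still open, it means among the compounds named here.

In a physicochemical assay for solubility, using the shake flask method, in simulated intestinal fluid, measured as kinetic solubility, with a stated time of 2 h, at 25 degrees C, at pH 6.5 (on this read-out higher numbers stand for higher solubility and lower numbers for lower solubility), compound 1 (`CCCOC(=O)c1nc(C)c2c(c1N)C(=O)N(Cc1ccccc1)C2=O`) gives < 5000 nM, which is a limit and not a number. Compound 2 (`Cc1noc(-c2nc(C)c3c(c2N)C(=O)N(Cc2ccc(F)cc2)C3=O)n1`) gives < 5000 nM, again a limit and not a number. Compound 2 therefore has no exact position and stands with compound 1 at the limit of < 5000 nM in this assay, at which 2 of the 2 values shown sit.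

Compound 3 (`Cc1noc(-c2nc(C)c3c(c2N)C(=O)N(Cc2ccc(Oc4ccc(F)cc4)cc2)C3=O)n1`) carries 4-fluorophenoxy in place of fluoro on an aromatic carbon, para to a large group: 4-fluorophenoxy in place of fluoro on an aromatic carbon. Among the measured compounds shown here, no measured pair of compounds differing in one place shows how large such a change tends to be, so what follows is a judgement. A modest downward move in this assay, not far beyond the usual scatter, is expected, and the estimated step is a step that the limit leaves unreadable from compound 2 to compound 3. Compound 3 is expected at about 2500 nM, with an estimated range from 800 nM to 5000 nM, and it may well be reported only as a limit.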

Compound 3, solubility: 23800 nM
Compound 3: the middle estimate sits 9.5-fold (0.98 log units) below what was measured; the whole stated range lies below it.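

In this assay, placing 4-fluorophenoxy on this aromatic carbon, para to a large group, gives an at least 4.7-fold higher number from compound 2 to compound 3 (0.67 log units; beyond the scatter). Compound 3 is therefore the first of the compounds shown with an exact number rather than a limit, and it shows that this much larger group, with its added aromatic ring, can go on this carbon without the read-out staying at the limit. The true size of the step stays unknown because compound 2 carries only a limit: the limit of < 5000 nM in this assay, at which 2 of the 3 values shown sit.

On these data alone, it remains open whether the higher number comes from the added ring or from the oxygen that joins it, and whether a methoxy group or an amine on the same carbon would read out similarly. As far as these compounds go, it is also open whether the same change would give a similar step on the core of compound 1.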